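A few compounds are considered here, and "the series" means these few. Any claim that something is new, unique, unknown or untested is made for them only; others in the source may bear on it.

Compound 1 `Cc1sc2nc(-c3ccccn3)c(/C=N/NC(=N)N)n2c1C` gives 33100 nM in a functional assay (Homo sapiens) for antiproliferative activity (on this read-out lower numbers stand for stronger inhibition of growth and higher numbers for weaker inhibition of growth), the highest number among the three measured compounds. Compound 2 `N=C(N)N/N=C/c1c(-c2ccccn2)nc2sc(Cl)cn12` gives 15100 nM in this assay, and compound 3 `N=C(N)N/N=C/c1c(-c2ccncc2)nc2sc(Cl)cn12` gives 13800 nM. Compound 4 `Cc1sc2nc(-c3ccncc3)c(/C=N/NC(=N)N)n2c1C` is not yet measured in this assay; it differs from compound 1 by pyridin-4-yl in place of pyridin-2-yl on an aromatic carbon. Going by the values given here, the one measured step that carries the same change, a 1.1-fold lower number from compound 2 to compound 3 (0.04 log units; within the scatter), lies within the scatter. On that basis no step beyond the scatter is expected from compound 1 to compound 4, and the number for compound 4 is expected to stay close to that of compound 1, a 1.1-fold lower number from compound 1 to compound 4 (0.03 log units; within the scatter). Compound 4 is therefore estimated at 31000 nM, with a range from 15000 nM to 64000 nM.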

Compound 4, concentration for total growth inhibition: 83200 nM
Compound 4: the middle estimate sits 2.7-fold (0.43 log units) below what was measured; the measured number lies above the stated range.
By their numbers in this assay, from the lowest: compounds 3 and 2 (each within the scatter of the next); then compound 1; then compound 4.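

On the core of compound 1, the position of the pyridine nitrogen registers in the growth read-out, with a 2.5-fold higher number from compound 1 to compound 4 (0.40 log units; beyond the scatter). The earlier pair showed no such difference, so a reading from one core does not transfer to the other for this change in this assay: the same change on two cores in this assay, a 1.1-fold lower number (0.04 log units; within the scatter) from compound 2 to compound 3 and a 2.5-fold higher number (0.40 log units; beyond the scatter) from compound 1 to compound 4, 2.8-fold (0.44 log units) apart, beyond the scatter of two such steps

The compounds shown leave open which feature of the two cores, the chloro group or the two methyl groups, accompanies this difference. Also open, as far as these compounds go, is how pyridin-3-yl or a plain phenyl ring would read at this position on either core.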